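The compounds below may be only part of what the source reports. "The series", "measured", "known", "first", "only" and "open" are said of these compounds alone.

Compound 1 `CNc1nc(N)nc2c1ncn2/C=C1/CC1(CO)CO` is the reference point of this small set. In an ADME assay on HFF cells (Homo sapiens) for cytotoxicity, with a stated time of 8 days (on this read-out higher numbers stand for lower toxicity in this test and lower numbers for higher toxicity in this test), compound 1 gives 265000 nM, the only number shown for the set. Compound 2 `Nc1nc(OCC(F)(F)F)c2ncn(/C=C3/CC3(CO)CO)c2n1` carries 2,2,2-trifluoroethoxy in place of methylamino on an aromatic carbon. In this assay, for the measured compounds named here, compound 2 gives > 300000 nM, which is a limit of the test and not a number, so compound 2 is the one value that sits at the limit of > 300000 nM in this assay, at which 1 of the 2 values shown sits. Going by the values given here, the single measured step, an at least 1.1-fold higher number from compound 1 to compound 2 (0.05 log units; that floor lies within the scatter), therefore cannot be told apart from repeat scatter.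

Compound 3 `CC(C)Sc1nc(N)nc2c1ncn2/C=C1/CC1(CO)CO` differs from compound 1 by isopropylsulfanyl in place of methylamino on an aromatic carbon. Among the compounds with values here, the only measured step at this carbon, from compound 1 to compound 2, bears on it and was not beyond the scatter; no measured compound carries isopropylsulfanyl. Compound 3 is therefore expected to show no step beyond the scatter, a 1.1-fold lower number from compound 1 to compound 3 (0.03 log units; within the scatter). Compound 3 is estimated at 250000 nM, with a range from 110000 nM to 400000 nM.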

Compound 3, half-maximal cytotoxic concentration: > 300000 nM
Compound 3: a limit, no number (the forecaster's own chance of this, stated with the estimate: 40%); middle value at least 1.2-fold (0.07 log units) from the limit.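

In this assay compound 3 gives a limit of the test and not a number, so the set now leans towards that limit: the limit of > 300000 nM in this assay, at which 2 of the 3 values shown sit.

Isopropylsulfanyl in place of methylamino gives an at least 1.1-fold higher number from compound 1 to compound 3 (0.05 log units; that floor lies within the scatter), so a second, different replacement on this aromatic carbon, one that enters with sulfur and without a hydrogen-bond donor, again shows only a floor that does not pass the scatter. Compound 2 and compound 3 both end at limits, and the step between them cannot be read.

Going by these compounds, how far the numbers of compound 2 and compound 3 lie past the limit remains open, so these two groups cannot be ranked against each other. On these data alone, it is also open whether another group on this carbon, such as a carboxylic acid or a longer amine chain, would move the number clearly down from that of compound 1.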